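Swapping a saturated ring for a pyrazole ring

The compounds below may be only part of what the source reports. "The series", "measured", "known", "first", "only" and "open" are said of these compounds alone.

Of the compounds shown here, two have been measured in a physicochemical assay for lipophilicity, using the shake flask method, measured as octanol-water partition, with a stated time of 30 min, at pH 7.4; a higher number here means a more lipophilic compound, a lower number a more polar compound. Compound 1 `Cc1cn(C)nc1[C@H](C)Nc1c(C(N)=O)nnc2ccc(-c3ccc(OCCCN(C)C)nc3)cc12` gives 2.1. Compound 2 `CNC(=O)c1nnc2ccc(-c3ccc(OCCCN(C)C)nc3)cc2c1N[C@@H](C)C1CCOCC1` gives 2.3. Going by the values given here, these two numbers lie within the usual scatter of each other, so compound 2 cannot be told apart from compound 1 on this assay; compound 1 also differs from compound 2 in more than one place, so no single step connects them.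

Compound 3 `CNC(=O)c1nnc2ccc(-c3ccc(OCCCN(C)C)nc3)cc2c1N[C@@H](C)c1nn(C)cc1C` has not been measured. It differs from compound 2 in one place: 1,4-dimethyl-1H-pyrazol-3-yl in place of oxan-4-yl on a saturated chain carbon bound to a nitrogen on an aromatic ring and a saturated chain carbon. Among the compounds with values here, no measured step covers this exact change. Compound 1, which carries the same 1,4-dimethyl-1H-pyrazol-3-yl group, gives 2.1, close to compound 2. The change is therefore expected to leave the distribution coefficient roughly where it is, with a step of a number 0.10 log units higher from compound 2 to compound 3 (within the scatter) that stays within the scatter. Compound 3 is estimated at 2.4, between 1.9 and 2.9.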

Compound 3, distribution coefficient: 2.3
Beside the measured number, compound 3's estimate is 0.10 log units above it, and the stated range covers the measured number.
By their numbers in this assay, from the lowest: compounds 1, 2 and 3 (each within the scatter of the next).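

In this assay, 1,4-dimethyl-1H-pyrazol-3-yl in place of oxan-4-yl on a saturated chain carbon bound to a nitrogen on an aromatic ring and a saturated chain carbon gives no change at the digits printed from compound 2 to compound 3 (within the scatter), so at this place a five-membered aromatic ring and a six-membered non-aromatic ring cannot be told apart in this pair. The amide can now be read as a single change too: methyl in place of hydrogen on an amide-type nitrogen gives a number 0.20 log units higher from compound 1 to compound 3 (within the scatter), again too small to count as a real difference. Nothing measured here offers an explanation for either result.

From the compounds shown here alone, whether this place stays as indifferent with a carboxylic acid or an amine in the ring's stead remains open. So does whether a longer chain than methyl on the amide nitrogen would move the number.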